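Series notes: ring-amine substitution and an aromatic amine-methyl addition

The source may hold more compounds than are shown below. What is called first, only, known or untested is meant among the compounds shown, and "the series" means these compounds.

Of the compounds shown here, two have numbers so far. Compound 1 `C=CC[C@@]12CCN[C@@H]1n1c3nc4ccc(O)cc4cc3c(=O)c3cccc2c31` carries a free amine nitrogen in its ring; in a functional assay on MSTO-211H cells (Homo sapiens) for inhibition, read by trypan blue exclusion, with a stated time of 72 h (on this read-out higher numbers stand for weaker inhibition of growth and lower numbers for stronger inhibition of growth), compound 1 gives 18700 nM. Compound 2 `C=CC[C@@]12CCN(C(=O)OC(C)(C)C)[C@@H]1n1c3nc4ccc(O)cc4cc3c(=O)c3cccc2c31` carries a tert-butoxycarbonyl on that nitrogen; in this assay compound 2 gives 24100 nM. The only step available is a 1.3-fold higher number from compound 1 to compound 2 (0.11 log units; within the scatter), so compound 2 stands alongside compound 1 rather than apart from it on the numbers shown.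

Compound 3 `C=CC[C@@]12CCN(C(=O)OC(C)(C)C)[C@@H]1n1c3nc4ccc(O)c(CN(C)C)c4cc3c(=O)c3cccc2c31` keeps the tert-butoxycarbonyl of compound 2 and differs from it by (dimethylamino)methyl in place of hydrogen on an aromatic carbon. Within the data shown here, no measured step touches this part of the core; the one step known, a 1.3-fold higher number from compound 1 to compound 2 (0.11 log units; within the scatter), concerns the ring-amine nitrogen and says nothing about an added (dimethylamino)methyl on the aromatic carbon. Among the measured compounds shown here, with no precedent, no step beyond the scatter is expected in this assay in either direction, and the estimate is held broad.

For compound 3 the expected step is a 1.2-fold lower number from compound 2 to compound 3 (0.08 log units; within the scatter) in this assay. Compound 3 is therefore estimated at 20000 nM, with a range from 6000 nM to 70000 nM.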

Compound 3, concentration for 50% growth inhibition: 22800 nM
The estimate for compound 3 lay 1.1-fold (0.06 log units) below the measured number; measured number inside the range.
By their numbers in this assay, from the lowest: compounds 1, 3 and 2 (each within the scatter of the next).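

In this assay, among these compounds, (dimethylamino)methyl in place of hydrogen on an aromatic carbon, ortho to a hydroxy group, gives a 1.1-fold lower number from compound 2 to compound 3 (0.02 log units; within the scatter) and thereby provides the first reading at this position, which the earlier pair, changed only at the ring-amine nitrogen, did not touch. With the tert-butoxycarbonyl kept on that nitrogen, adding this group of 4 heavy atoms produces no step beyond the scatter, so changes at two separate places on the shared core have now each left the number within the scatter. No measured evidence bearing on this result is available.

Still open, from the compounds shown here alone, is whether (dimethylamino)methyl at this aromatic carbon would read the same on the free ring amine of compound 1, since the present step was read only with the tert-butoxycarbonyl in place. Also open, going by these compounds, is how this carbon would respond to a different group, such as a morpholinomethyl, a carboxylic acid or a longer aminoalkyl chain, in place of (dimethylamino)methyl.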